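A few compounds are considered here, and "the series" means these few. Any claim that something is new, unique, unknown or untested is made for them only; others in the source may bear on it.

Of the compounds shown here, three from this series have been measured in an assay for inhibition of Fatty-acid amide hydrolase 1 (Rattus norvegicus); on this read-out lower numbers stand for stronger inhibition and higher numbers for weaker inhibition. Compound 1 `NC(=O)c1cccc(-c2cnc(C(=O)CCc3ccc(-c4ccccc4)cc3)o2)n1` gives 1.2 nM, compound 2 `COC(=O)c1ccc(-c2cnc(C(=O)CCc3ccc(-c4ccccc4)cc3)o2)cn1` gives 0.6 nM, and compound 3 `O=C(O)c1ccc(-c2cnc(C(=O)CCc3ccc(-c4ccccc4)cc3)o2)cn1` gives 44 nM, the highest of the three numbers; the next nearest is a 37-fold higher number from compound 1 to compound 3 (1.56 log units; beyond the scatter), and the furthest is a 73-fold higher number from compound 2 to compound 3 (1.87 log units; beyond the scatter). Compound 4 `COC(=O)c1cnc(C(=O)CCc2ccc(-c3ccccc3)cc2)o1` is the next step: methoxycarbonyl in place of 6-carboxypyridin-3-yl on an aromatic carbon. The step bearing most on it is a 73-fold higher number from compound 2 to compound 3 (1.87 log units; beyond the scatter), where the methyl ester stood far stronger than the acid; the contrast a 2.0-fold lower number from compound 1 to compound 2 (0.30 log units; within the scatter) was within the scatter. Within the data shown here, no measured pair tells what removing the pyridine ring itself does. Compound 4 is therefore expected to give a clearly lower number than compound 3, as an 8.8-fold lower number from compound 3 to compound 4 (0.94 log units; beyond the scatter). The estimate for compound 4 in this assay is 5 nM, ranging from 1 nM to 30 nM.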

Compound 4, inhibition constant: 1.5 nM
The estimate for compound 4 lay 3.3-fold (0.52 log units) above the measured number, and the stated range covers the measured number.
By their numbers in this assay, from the lowest: compounds 2, 1 and 4 (each within the scatter of the next, the first and the last beyond it); then compound 3.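

At this carbon next to the ring oxygen, a large aromatic group is not needed for a low number: methoxycarbonyl, which has no ring, replaces 6-carboxypyridin-3-yl with a large gain (a 29-fold lower number from compound 3 to compound 4 (1.47 log units; beyond the scatter)) and matches the 6-carbamoylpyridin-2-yl group within the scatter (a 1.3-fold higher number from compound 1 to compound 4 (0.10 log units; within the scatter)). The 6-(methoxycarbonyl)pyridin-3-yl group still keeps a modest edge (a 2.5-fold higher number from compound 2 to compound 4 (0.40 log units; beyond the scatter)). No evidence is available to explain these differences.

As far as these compounds go, what a carboxylic acid attached directly at this carbon would give remains open. So does the effect of a primary amide there.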